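The source may hold more compounds than are shown below. What is called first, only, known or untested is meant among the compounds shown, and "the series" means these compounds.

Of the compounds shown here, three sharing one core have been measured in an assay on isolated protein with malate dehydrogenase, mitochondrial (Sus scrofa) as the target; a lower number here means a stronger inhibitor, a higher number a weaker inhibitor. Compound 1 `O=C(O)c1cnc2cc(OCCOc3ccc(F)cc3)ccc2c1O` gives 18200 nM and compound 3 `O=C(O)c1cnc2cc(OCc3ccc(Cl)c(Cl)c3)ccc2c1O` gives 4790 nM, while compound 2 `O=C(O)c1cnc2cc(O)ccc2c1O` gives 490000 nM, the highest number of the three and beyond the scatter from both others, so compound 2 is the weakest inhibitor here. Compound 4 `NC(=O)c1ccc2c(O)c(C(=O)O)cnc2c1` has not yet been measured in this assay. It differs from compound 2 by carbamoyl in place of hydroxy on an aromatic carbon. A reason to expect some gain is that compound 1 gives 18200 nM and compound 3 gives 4790 nM, both far below compound 2, although no step to a carbamoyl is known. Compound 4 is expected to show a modest step toward stronger inhibition, a 2.5-fold lower number from compound 2 to compound 4 (0.39 log units; beyond the scatter). Compound 4 is estimated at 200000 nM, between 50000 nM and 600000 nM.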

Compound 4, half-maximal inhibitory concentration: 741000 nM
The estimate for compound 4 lay 3.7-fold (0.57 log units) below the measured number, and the stated range ends below it.
By their numbers in this assay, from the lowest: compound 3; then compound 1; then compounds 2 and 4 (each within the scatter of the next).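

In this assay, carbamoyl in place of hydroxy on this aromatic carbon gives a 1.5-fold higher number from compound 2 to compound 4 (0.18 log units; within the scatter), so this single exchange does not separate the two compounds. Within the data shown here, at this position, then, the carbamoyl group offers no measurable gain over hydroxy, a reading that the earlier compounds, with no direct step among them, could not give. Nothing available explains this result. Going by these compounds, whether an amine, a nitrile or a methoxy group on this same carbon would read any differently remains open. So does whether a substituted amide, carrying a benzyl group on its nitrogen, would behave like the plain carbamoyl.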